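The source may hold more compounds than are shown below. What is called first, only, known or untested is meant among the compounds shown, and "the series" means these compounds.

Series notes: in a functional assay on NCI/ADR cells (Homo sapiens) for cytotoxicity, read by sulforhodamine B assay (a higher number here means a weaker inhibitor of growth, a lower number a stronger inhibitor of growth), compound 1 (`COc1ccc(/C=N\NC(=S)NC(C)(C)CCC[C@](C)(O)[C@@H]2CC=C(C)CC2)cc1`) gives 6730 nM while compound 2 (`CC1=CC[C@@H]([C@@](C)(O)CCCC(C)(C)NC(=S)N/N=C\c2ccc(N(C)C)cc2)CC1`) gives 25200 nM and compound 3 (`CC1=CC[C@@H]([C@@](C)(O)CCCC(C)(C)NC(=S)N/N=C\c2ccccc2[N+](=O)[O-])CC1`) gives 20400 nM as the series stands. Compound 3 sits with compound 2 at the high end of these numbers (a 1.2-fold lower number from compound 2 to compound 3 (0.09 log units; within the scatter)) and apart from compound 1 (a 3.0-fold higher number from compound 1 to compound 3 (0.48 log units; beyond the scatter)). Compound 4 (`CC1=CC[C@@H]([C@@](C)(O)CCCC(C)(C)NC(=S)N/N=C\c2cccc(Cl)c2)CC1`) differs from it by one change (3-chlorophenyl in place of 2-nitrophenyl on a carbon with a double bond to nitrogen): 3-chlorophenyl in place of 2-nitrophenyl on a carbon with a double bond to nitrogen. The other measured changes on the phenyl group gave modest steps (a 3.7-fold higher number from compound 1 to compound 2 (0.57 log units; beyond the scatter)) or none beyond the scatter. Within the data shown here, none of the measured compounds carries chlorine, so only a small move towards a lower number is expected in this assay. The estimated change is modest (a 1.5-fold lower number from compound 3 to compound 4 (0.16 log units; within the scatter)). Compound 4 is estimated at 14000 nM (expected range 6000 nM to 30000 nM).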

Compound 4, concentration for 50% growth inhibition: 7350 nM
Compound 4: middle estimate off by 1.9-fold (0.28 log units), on the high side; low and high end bracket the measured number.
By their numbers in this assay, from the lowest: compounds 1 and 4 (each within the scatter of the next); then compounds 3 and 2 (each within the scatter of the next).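

In this assay, 3-chlorophenyl on a carbon with a double bond to nitrogen gives a 2.8-fold lower number from compound 3 to compound 4 (0.44 log units; beyond the scatter) and also a 3.4-fold lower number from compound 2 to compound 4 (0.54 log units; beyond the scatter), whereas against 4-methoxyphenyl it gives a 1.1-fold higher number from compound 1 to compound 4 (0.04 log units; within the scatter). The low end of the series at this position therefore no longer rests on compound 1 alone, and two different groups now share it. Nothing available accounts for the gaps between these groups.

As far as these compounds go, whether the chlorine itself or its place on the ring counts stays open. From the compounds shown here alone, how a carboxylic acid or a longer alkyl chain on the phenyl group would read is also open.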